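The source may hold more compounds than are shown below. What is called first, only, known or untested is meant among the compounds shown, and "the series" means these compounds.

Measured in an assay for inhibition of histone-lysine N-methyltransferase, H3 lysine-79 specific (Homo sapiens), with stated times of 15 min and 120 min, tested at 50 uM; a higher number here means more inhibition at the concentration tested (going by the name of the read-out), a lower number less inhibition:
- compound 1 `Cc1cccc(OCc2nn3c(Cn4nnc5ccccc54)nnc3s2)c1`: 50%
- compound 2 `CCCc1nnc2sc(-c3cccc(F)c3)nn12`: 35%
- compound 3 `Fc1cccc(-c2nn3c(CSc4ccccc4)nnc3s2)c1`: 21%

Compound 3 stands lowest of the three numbers in this assay; the nearest is compound 2, higher by a step beyond the scatter, and the furthest is compound 1, also beyond the scatter. Compound 4 `Fc1cccc(-c2nn3c(CN4CCCCC4)nnc3s2)c1` differs from compound 3 by piperidin-1-yl in place of phenylsulfanyl on a saturated chain carbon bound to an aromatic carbon. Among the measured compounds shown here, the only measured step that bears on this is a number 14 percentage points lower from compound 2 to compound 3 (beyond the scatter), where phenylsulfanyl entered in place of ethyl on a saturated chain carbon bound to an aromatic carbon and the number fell modestly. Compound 4 removes that phenylsulfanyl again and sets piperidin-1-yl there, so the change partly undoes the step that led to compound 3; compound 1, which carries yet another group on a saturated chain carbon bound to an aromatic carbon, sits higher still. For the measured compounds named here, no measured pair shows piperidin-1-yl itself, so the direction rests on this alone. Expected is a modest rise in this assay, a step of a number 9 percentage points higher from compound 3 to compound 4 (within the scatter), which may fall within the scatter. Compound 4 is estimated at 30%, between 12% and 48%.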

Compound 4, a percentage reported as inhibition, at one concentration (the size of the read-out at that concentration, not a potency): 6%
Beside the measured number, compound 4's estimate is 24 percentage points above it, and the stated range ends above it.
By their numbers in this assay, from the lowest: compound 4; then compound 3; then compound 2; then compound 1.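

In this assay, the saturated chain carbon bound to an aromatic carbon now has three groups to compare on the same core: ethyl, phenylsulfanyl and piperidin-1-yl. The change to a non-aromatic ring gives a number 15 percentage points lower from compound 3 to compound 4 (beyond the scatter), so swapping out the aromatic ring of carbon only does not bring the number back, and measured against ethyl, piperidin-1-yl gives a number 29 percentage points lower from compound 2 to compound 4 (beyond the scatter). Among these three compounds, both groups carrying a six-membered ring therefore stand below ethyl, and nothing shown explains either step.

On these data alone, whether a longer open chain such as butyl would stand above or below ethyl at this place remains open. So does the effect of a carboxylic acid or an open-chain amine such as dimethylamino on the read-out.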